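This account rests on a few compounds, and the source may have more. Where it says the series, first, only, none or still open, it means among the compounds named here.

Measured so far, in a physicochemical assay for solubility; a higher number here means a more soluble compound, a lower number a less soluble compound:
- compound 1 `Nc1nc(C(F)(F)F)cc2c1[nH]c(=O)n2CC1CCCOC1` gives 37 ug/mL
- compound 2 `Cc1cccc(Cn2c(=O)[nH]c3c(N)nc(C(F)(F)F)cc32)n1` gives 3 ug/mL
- compound 3 `Cc1cc(Cn2c(=O)[nH]c3c(N)nc(C(F)(F)F)cc32)no1` gives 4 ug/mL

Compound 3 sits well below compound 1, the step being a 9.3-fold lower number from compound 1 to compound 3 (0.97 log units; beyond the scatter), while against compound 2 it lies within the scatter, as shown by a 1.3-fold higher number from compound 2 to compound 3 (0.12 log units; within the scatter). Compound 4 `Cc1nc(Cn2c(=O)[nH]c3c(N)nc(C(F)(F)F)cc32)co1` is the next step: 2-methyl-1,3-oxazol-4-yl in place of 5-methyl-1,2-oxazol-3-yl on a saturated chain carbon bound to an aromatic nitrogen. Within the data shown here, no measured step exchanges one five-membered aromatic ring for another of the same atom count, so none bears directly on it. The two steps out of compound 1, a 12-fold lower number from compound 1 to compound 2 (1.09 log units; beyond the scatter) and a 9.3-fold lower number from compound 1 to compound 3 (0.97 log units; beyond the scatter), were both large and came from replacing the oxan-3-yl, which is not what happens here; the step of a 1.3-fold higher number from compound 2 to compound 3 (0.12 log units; within the scatter), where one methyl-bearing aromatic ring stands in for another, stayed within the scatter. On that basis the step in this assay is expected to be a 1.3-fold higher number from compound 3 to compound 4 (0.10 log units; within the scatter), none beyond the scatter. Compound 4 is therefore estimated at 5 ug/mL, between 2 ug/mL and 12 ug/mL.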

Compound 4, solubility: 35 ug/mL
Compound 4: the middle estimate sits 7.0-fold (0.85 log units) below what was measured; the measured number lies above the stated range.
By their numbers in this assay, from the lowest: compounds 2 and 3 (each within the scatter of the next); then compounds 4 and 1 (each within the scatter of the next).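

In this assay, at this position, on a saturated chain carbon bound to an aromatic nitrogen, joining the same atoms differently in the ring is enough to produce a step beyond the scatter (an 8.8-fold higher number from compound 3 to compound 4 (0.94 log units; beyond the scatter)). The 2-methyl-1,3-oxazol-4-yl also stands clear of the 6-methylpyridin-2-yl (a 12-fold higher number from compound 2 to compound 4 (1.07 log units; beyond the scatter)) but lies within the scatter of the oxan-3-yl (a 1.1-fold lower number from compound 1 to compound 4 (0.02 log units; within the scatter)), so among these four compounds an aromatic ring here does not always go with the low numbers of compound 2 and compound 3. Nothing shown here explains the gap between the two five-membered rings.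

The compounds shown leave open whether the methyl of the 2-methyl-1,3-oxazol-4-yl matters in this assay, as a plain 1,3-oxazol-4-yl would show. They also leave open whether a 2-methyl-1,3-thiazol-4-yl would stand with compound 4 or with compound 3.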